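Lengthening a Ketone Side Chain in a Receptor Modulator

The compounds below may be only part of what the source reports. "The series", "measured", "known", "first", "only" and "open" are said of these compounds alone.

Going by the values given here, compound 1 `COc1ccc(C(=O)O)cc1OCCCCOc1ccc(C(=O)C(C)C)c(O)c1C` is the only member of this small set with a numerical result. In an assay on HEK293 cells for positive allosteric modulation of metabotropic glutamate receptor 2 (Rattus norvegicus), read by thallium flux, with a stated time of 2.5 min (a higher number here means that more compound is needed for the effect, a lower number that less compound is needed), compound 1 gives 116 nM, which places it as the sole reference point, since the other measured entry carries no number. Compound 2 `Cc1c(OCCCCOc2cccc(C(=O)O)c2)ccc(C(=O)CC(C)C)c1C` belongs to the same series but differs from compound 1 in several places at once. In this assay, among the compounds with values here, compound 2 is reported as "not active" (no number reported), so it offers no figure to compare with and no single-change step can be drawn between compound 2 and compound 1.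

Compound 3 `COc1ccc(C(=O)O)cc1OCCCCOc1ccc(C(=O)CC(C)C)c(O)c1C` has not been measured. Its structure differs from that of compound 1 in one place: isobutyl in place of isopropyl on a carbonyl carbon. Within the data shown here, no step between two measured compounds shows what this kind of change does here. Because compound 1 gives 116 nM and compound 2 with an isobutyl ketone is inactive only alongside other alterations, the expected step from compound 1 to compound 3 is a 1.6-fold higher number from compound 1 to compound 3 (0.19 log units; within the scatter), a modest loss that may not exceed the usual scatter. Compound 3 is therefore estimated at 180 nM, within a range from 60 nM to 600 nM.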

Compound 3, half-maximal effective concentration: 155 nM
Compound 3: middle estimate off by 1.2-fold (0.06 log units), on the high side; low and high end bracket the measured number.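

In this assay, replacing isopropyl with isobutyl on a carbonyl carbon now has a measured size, a 1.3-fold higher number from compound 1 to compound 3 (0.13 log units; within the scatter), so this one-carbon extension of the ketone side chain cannot be told apart from repeat-measurement noise. With the rest of the structure held fixed, compound 3 shows that an isobutyl ketone on this core still gives a measurable number, so the isobutyl group alone does not abolish the effect here. The data shown include no measurement that would explain why this step is so small.

Going by these compounds alone, compound 2 differs from compound 1 and compound 3 in several places and has no number, so no step involving it can be read, and which of its differences goes with its "not active" report remains open. Also open, going by these compounds, is how far this carbonyl position can be extended or reshaped, for example whether a tert-butyl group, a cyclopentyl ring or a longer chain such as n-hexyl would keep the result in this range, since two closely related side chains cannot show where such a trend would end.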